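Removing one methoxy from the aromatic ring in the series

The source may report more compounds than this note shows. Statements on the series, on what has been measured and on what is new or still open speak of the compounds shown alone.

Three measured compounds share one core and differ only in the methoxy pattern on the aromatic ring. Compound 1 `COc1cc(C=C2C(=O)N(c3ccc(Cl)cc3)N(c3ccc(Cl)cc3)C2=O)cc(OC)c1OC` carries three methoxy groups, compound 2 `COc1ccc(C=C2C(=O)N(c3ccc(Cl)cc3)N(c3ccc(Cl)cc3)C2=O)cc1OC` two, and compound 3 `COc1cccc(C=C2C(=O)N(c3ccc(Cl)cc3)N(c3ccc(Cl)cc3)C2=O)c1OC` two in another arrangement. In a functional assay on ECa-109 cells (Homo sapiens) for cytotoxicity, read by MTT assay, with a stated time of 72 h (a lower number here means a stronger inhibitor, a higher number a weaker inhibitor), compound 1 gives 10100 nM. Compound 2 reaches only a limit of this assay, > 128000 nM, and this is a limit and not a number (the limit of > 128000 nM in this assay, at which 1 of the 3 values shown sits). Compound 3 gives 6800 nM in this assay, which lies within the scatter of the number for compound 1.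

The change hydrogen in place of methoxy on an aromatic carbon produced an at least 12-fold higher number from compound 1 to compound 2 (1.10 log units; beyond the scatter). Going on, an at least 18-fold lower number from compound 2 to compound 3 (1.27 log units; beyond the scatter), so moving both methoxy groups recovers the loss. How compound 3 relates to compound 1 is not broken down here, as the two differ in more than one place.

Compound 4 `COc1ccccc1C=C1C(=O)N(c2ccc(Cl)cc2)N(c2ccc(Cl)cc2)C1=O` has not been measured. It differs from compound 3 by hydrogen in place of methoxy on an aromatic carbon. This is the same kind of change as from compound 1 to compound 2, not the same: in compound 1 the leaving methoxy is also meta to a methoxy group, in compound 3 it is not. Compound 4 is expected to give a higher number than compound 3 because the same kind of change in compound 1 gave an at least 12-fold higher number from compound 1 to compound 2 (1.10 log units; beyond the scatter). The expected step is a 5.1-fold higher number from compound 3 to compound 4 (0.71 log units; beyond the scatter), smaller than that earlier one since only a single methoxy remains as a neighbour. Compound 4 is estimated at 35000 nM, between 9000 nM and 128000 nM.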

Compound 4, half-maximal inhibitory concentration: 30400 nM
Beside the measured number, compound 4's estimate is 1.2-fold (0.06 log units) above it; the range from low to high includes it.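

In this assay hydrogen in place of methoxy on an aromatic carbon gives a higher number on both cores, with the new step being a 4.5-fold higher number from compound 3 to compound 4 (0.65 log units; beyond the scatter) and the size of the change not carrying over unchanged from one core to the other: the same change on two cores in this assay, an at least 12-fold higher number (1.10 log units; beyond the scatter) from compound 1 to compound 2 and a 4.5-fold higher number (0.65 log units; beyond the scatter) from compound 3 to compound 4, at least 2.8-fold (0.45 log units) apart, beyond the scatter of two such steps. The direction of the change therefore held on these two cores, but its size did not, and two cores cannot show why the sizes differ or what a third core would do. The wider swap is a separate matter, with an at least 4.2-fold lower number from compound 2 to compound 4 (0.62 log units; beyond the scatter) and 2-methoxyphenyl replacing 3,4-dimethoxyphenyl, so this step does not isolate a single methoxy, and the value for compound 2 in it is a limit and not a number: the limit of > 128000 nM in this assay, at which 1 of the 4 values shown sits.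

The compounds shown leave open whether ethoxy or hydroxy in place of the remaining methoxy of compound 4 would follow the same direction, and what a plain phenyl with no methoxy at all would give. They also leave open whether these steps would hold if an amine or a methyl took the place of chlorine on the two chlorophenyl groups of the shared core.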